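Replacing Ethoxy with an Aryl Amine on the Carbonyl

The compounds below may be only part of what the source reports. "The series", "measured", "known", "first", "only" and "open" are said of these compounds alone.

Compound 1 `COc1ccc(C(=O)CSc2nnc(-c3cc(OC)c(OC)c(OC)c3)n2-c2ccc(N(C)C)cc2)cc1` gives 18800 nM
Compound 2 `CCOC(=O)CSc1nnc(-c2cc(OC)c(OC)c(OC)c2)n1-c1ccc(N(C)C)cc1` gives > 60000 nM

In a functional assay on HepG2 cells (Homo sapiens) for inhibition, read by MTT assay, with a stated time of 48 h (on this read-out higher numbers stand for weaker inhibition and lower numbers for stronger inhibition), compound 2 stands at > 60000 nM as a limit of the assay, not a number. Compound 3 `COc1cc(-c2nnc(SCC(=O)Nc3ccc(Cl)cc3)n2-c2ccc(N(C)C)cc2)cc(OC)c1OC` is still unmeasured and differs on a carbonyl carbon, by (4-chlorophenyl)amino in place of ethoxy on a carbonyl carbon in words: (4-chlorophenyl)amino in place of ethoxy. For the measured compounds named here, one measured step bears on this carbon, an at least 3.1-fold higher number from compound 1 to compound 2 (0.50 log units; beyond the scatter) and beyond the scatter. Going by the values given here, with only that step to go on, a lower number of similar size is expected in this assay on leaving ethoxy. The expected change is an at least 3.0-fold lower number from compound 2 to compound 3 (0.47 log units; beyond the scatter) on this estimate. For compound 3 20000 nM is the estimated value, expected between 6000 nM and 60000 nM in this reading.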

Compound 3, half-maximal inhibitory concentration: > 60000 nM
Compound 3 was reported as a limit; the forecaster's own chance of this, stated with the estimate: 20%; middle value at least 3.0-fold (0.47 log units) away from the limit.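

In this assay, (4-chlorophenyl)amino in place of 4-methoxyphenyl on the carbonyl carbon gives an at least 3.1-fold higher number from compound 1 to compound 3 (0.50 log units; beyond the scatter). Compound 3 also carries a six-membered aromatic ring on this carbon, so such a ring alone does not retain the inhibition seen with compound 1. The change from ethoxy to (4-chlorophenyl)amino cannot be read, because compound 2 and compound 3 both stand at a limit of the assay, not a number: the limit of > 60000 nM in this assay, at which 2 of the 3 values shown sit.

Going by these compounds, it remains open whether the loss from compound 1 follows the nitrogen link or the ring substituent. A 4-chlorophenyl group directly on the carbonyl carbon, or a (4-methoxyphenyl)amino group there, would separate the two.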